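Chloro Removal on a Shared Core: Growth Inhibition Notes

A few compounds are considered here, and "the series" means these few. Any claim that something is new, unique, unknown or untested is made for them only; others in the source may bear on it.

Compound 1 `ClCc1ccccc1Cn1cnc2c(Cl)nc(Cl)nc21` and compound 3 `ClCc1ccc(Cn2cnc3nc(Cl)nc(Cl)c32)cc1` have the same atoms joined differently; the difference between the two cores is not broken down here. In a functional assay on A498 cells (Homo sapiens) for cytotoxicity, read by sulforhodamine B assay, with a stated time of 48 h (a lower number here means a stronger inhibitor of growth, a higher number a weaker inhibitor of growth), compound 1 gives 2400 nM, while compound 3 gives 11200 nM. Compound 2 `ClCc1ccccc1Cn1cnc2c(Cl)ncnc21` differs from compound 1 by hydrogen in place of chloro on an aromatic carbon; in this assay compound 2 gives 17400 nM, the step being a 7.3-fold higher number from compound 1 to compound 2 (0.86 log units; beyond the scatter). Compound 4 `ClCc1ccc(Cn2cnc3ncnc(Cl)c32)cc1` is not yet measured and differs from compound 3 by hydrogen in place of chloro on an aromatic carbon, the same change at the same place. Going by the values given here, the step is expected to repeat as a 6.3-fold higher number from compound 3 to compound 4 (0.80 log units; beyond the scatter), resting on the single earlier instance a 7.3-fold higher number from compound 1 to compound 2 (0.86 log units; beyond the scatter), with some allowance for the unknown behaviour of the other core. Compound 4 is accordingly estimated at 70000 nM, with a range from 25000 nM to 200000 nM.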

Compound 4, concentration for 50% growth inhibition: 1810 nM
Compound 4: middle estimate off by 39-fold (1.59 log units), on the high side, outside the stated range (below it).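

On the core of compound 3, hydrogen in place of chloro gives a 6.2-fold lower number from compound 3 to compound 4 (0.79 log units; beyond the scatter) in this assay, so the change does not carry over from the core of compound 1, where the step runs the other way: the same change on two cores in this assay, a 7.3-fold higher number (0.86 log units; beyond the scatter) from compound 1 to compound 2 and a 6.2-fold lower number (0.79 log units; beyond the scatter) from compound 3 to compound 4, 45-fold (1.65 log units) apart, beyond the scatter of two such steps

A step measured on one of these cores therefore gives no safe estimate for the other. Going by these compounds alone, with only one pair per core, these data show the opposite directions for these four compounds but not the reason for the reversal, nor any rule for further cores.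

Going by these compounds, it remains open how either core responds when an amine or a methoxy group replaces the chloro on this aromatic carbon. On these data alone, it also remains open whether any such step would again differ between the two cores.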